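The source may report more compounds than this note shows. Statements on the series, on what has been measured and on what is new or still open speak of the compounds shown alone.

Compound 1 `CCC[C@@H]1NC(=O)[C@@H](C(C)C)NC(=O)[C@@H](C)NCCOc2ccccc2/C=C/CNC1=O`: > 10000 nM
Compound 2 `CCC[C@@H]1NC(=O)[C@@H](C(C)C)NC(=O)[C@@H](CCCCN)NCCOc2ccccc2/C=C/CNC1=O`: > 10000 nM

In an assay on isolated protein for displacement of a labelled ligand from Motilin receptor (Homo sapiens) (a lower number here means a stronger inhibitor, a higher number a weaker inhibitor), compound 1 reaches only the limit of the assay, > 10000 nM. Compound 2 likewise stands at a limit, > 10000 nM. The step that the two limits leave unreadable from compound 1 to compound 2 is therefore unreadable, both values sitting at the limit of > 10000 nM in this assay, at which 2 of the 2 values shown sit. Compound 3 `CCC[C@@H]1NC(=O)[C@@H](C(C)C)NC(=O)[C@@H](CCC(=O)O)NCCOc2ccccc2/C=C/CNC1=O` differs from compound 2 by carboxy in place of 2-aminoethyl on a saturated chain carbon, two bonds along the chain from a saturated ring carbon. Going by the values given here, no measured step bears on this exchange, and no compound has yet given a number. Compound 3 is therefore expected to remain at the limit as well, the estimate being 20000 nM, range 5000 nM to 100000 nM. The expected step that the limit leaves unreadable from compound 2 to compound 3 is thus not one that a limit can show.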

Compound 3, inhibition constant: > 10000 nM
Compound 3: a limit, no number; the forecaster's own chance of this, stated with the estimate: 85%; the middle value lies beyond the limit too.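

In this assay, going by these compounds alone, compound 1, compound 2 and compound 3 all stand at a limit, so no step among them can be read: the limit of > 10000 nM in this assay, at which 3 of the 3 values shown sit. The compounds shown leave open whether any of these exchanges changes binding at all.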